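Bromo to iodo on the phenyl ring: working notes

This account rests on a few compounds, and the source may have more. Where it says the series, first, only, none or still open, it means among the compounds named here.

- compound 1 `COc1ccccc1Oc1c(N)nc(-c2cccc(C)c2)nc1Cl` gives 13100 nM
- compound 2 `COc1ccccc1Oc1c(N)nc(-c2ccc(Br)cc2)nc1Cl` gives 4440 nM
- compound 3 `COc1ccccc1Oc1c(N)nc(-c2ccc(I)cc2)nc1Cl` is not yet measured

In a functional assay on B16 cells (Mus musculus) for cytotoxicity, read by CCK-8 assay, with a stated time of 24 h (on this read-out higher numbers stand for weaker inhibition and lower numbers for stronger inhibition), compound 2 stands lowest of the two numbers at 4440 nM with compound 1 the nearest. Compound 3 carries iodo in place of bromo on an aromatic carbon, para to a large group (iodo in place of bromo on an aromatic carbon). Among the measured compounds shown here, the only measured step is a 3.0-fold lower number from compound 1 to compound 2 (0.47 log units; beyond the scatter) and it is modest, beyond the scatter. That step, 4-bromophenyl in place of 3-methylphenyl, exchanges no halogen, so it bears only loosely. A smaller step, slightly downward and probably within the scatter, is expected: a 1.3-fold lower number from compound 2 to compound 3 (0.10 log units; within the scatter) in this estimate. For compound 3 the estimated value is 3500 nM with 1500 nM to 8000 nM as the expected range.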

Compound 3, half-maximal inhibitory concentration: 5400 nM
The estimate for compound 3 lay 1.5-fold (0.19 log units) below the measured number, and the stated range covers the measured number.
By their numbers in this assay, from the lowest: compounds 2 and 3 (each within the scatter of the next); then compound 1.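

In this assay, iodo in place of bromo on the aromatic carbon para to a large group gives a 1.2-fold higher number from compound 2 to compound 3 (0.09 log units; within the scatter), so this position does not tell the two halogens apart. The 4-iodophenyl group gives a 2.4-fold lower number from compound 1 to compound 3 (0.38 log units; beyond the scatter), which means a second halogen now also stands apart from 3-methylphenyl. No supporting data bear on why these numbers fall as they do.

Open, as far as these compounds go, is how a methyl, an amine or a carboxylic acid on that same carbon would compare with the two halogens. Also open, from the compounds shown here alone, is whether the separation from compound 1 follows the halogen itself or its place on the ring.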